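The source may hold more compounds than are shown below. What is called first, only, known or untested is meant among the compounds shown, and "the series" means these compounds.

Measured so far in an ADME assay on HEK293 cells (Homo sapiens) for cytotoxicity, read by MTT assay, with a stated time of 24 h; on this read-out lower numbers stand for stronger inhibition and higher numbers for weaker inhibition:
- compound 1 `CN(C)CCCNc1nc2cc([N+](=O)[O-])ccc2nc1NCc1ccc(Br)cc1`: 9.63 ug/mL
- compound 2 `Cc1ccc(CNc2nc3ccc([N+](=O)[O-])cc3nc2NCCCN(C)C)cc1`: 15.8 ug/mL

In this assay, compound 2 gives 15.8 ug/mL, which is within the scatter of compound 1, so the two values do not separate. The next compound to be measured is compound 3 `CN(C)CCCNc1nc2cc([N+](=O)[O-])ccc2nc1NCc1ccccc1Br`. Relative to compound 2 it carries this change: 2-bromophenyl in place of 4-methylphenyl on a saturated chain carbon bound to a nitrogen on an aromatic ring. In words, 2-bromophenyl stands in place of 4-methylphenyl.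

For the measured compounds named here, only one measured step bears on this: a 1.6-fold higher number from compound 1 to compound 2 (0.22 log units; within the scatter). That step is methyl in place of bromo on an aromatic carbon, so it is small and offers only partial guidance. Going by the values given here, no measured compound carries the 2-bromophenyl group itself, so the data do not show what this particular group does in this assay. No step beyond the scatter is therefore expected, and the estimate stays close to the two measured values.

The expected change is a 1.4-fold lower number from compound 2 to compound 3 (0.16 log units; within the scatter). For compound 3 the estimated value is 11 ug/mL, with an expected range of 5 ug/mL to 24 ug/mL.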

Compound 3, half-maximal inhibitory concentration: 51.9 ug/mL
Compound 3: middle estimate off by 4.7-fold (0.67 log units), on the low side; measured number outside the range, above it.
By their numbers in this assay, from the lowest: compounds 1 and 2 (each within the scatter of the next); then compound 3.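

In this assay, for the compounds shown here, the aryl group on a saturated chain carbon bound to a nitrogen on an aromatic ring now gives the first steps beyond the scatter: 2-bromophenyl in place of 4-bromophenyl (a 5.4-fold higher number from compound 1 to compound 3 (0.73 log units; beyond the scatter)) and 2-bromophenyl in place of 4-methylphenyl (a 3.3-fold higher number from compound 2 to compound 3 (0.52 log units; beyond the scatter)). The first of these keeps bromine in the group and changes only its place on the phenyl ring, so this position responds to where the bromine stands, whereas methyl in place of bromo on the same aromatic carbon stayed within the scatter (a 1.6-fold higher number from compound 1 to compound 2 (0.22 log units; within the scatter)). No measurement shown accounts for this difference.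

The compounds shown leave open whether the higher number belongs to bromine specifically or would also appear with 2-methylphenyl, 2-chlorophenyl or 2-methoxyphenyl, and where 3-bromophenyl would fall relative to the 2-bromophenyl and 4-bromophenyl compounds. They also leave open whether the same gap between compound 1 and compound 3 would hold if a morpholine or a shorter chain stood in place of the dimethylaminopropyl chain.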